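The compounds below may be only part of what the source reports. "The series", "measured", "known", "first", "only" and "open" are said of these compounds alone.

In an in vitro ADME assay on microsomes (Rattus norvegicus) for metabolic stability (a lower number here means that the compound disappears faster, a higher number that the compound lasts longer), compound 1 `CCc1nc(-c2ccc(OC(F)(F)F)cc2OC)c(CC)nc1NC(CC)CC` gives 0.0417 h as its reading. Compound 2 `CCc1nc(-c2ccc(C)cc2OC)c(CC)nc1NC(CC)CC` reads < 0.0167 h as a limit of the assay and not a number. Compound 2 thus stands on the limit of < 0.0167 h in this assay, at which 1 of the 2 values shown sits, and has no exact position. Compound 3 `CCc1nc(-c2ccc(OC(C)C)cc2OC)c(CC)nc1NC(CC)CC` brings isopropoxy in place of methyl on an aromatic carbon with isopropoxy in place of methyl on an aromatic carbon. Within the data shown here, the one measured step bearing on this, an at least 2.4-fold lower number from compound 1 to compound 2 (0.39 log units; beyond the scatter), exchanged trifluoromethoxy for methyl on that carbon. It is only a loose guide, so a modest rise in this assay is expected. The estimated move is an at least 1.3-fold higher number from compound 2 to compound 3 (0.11 log units; that floor lies within the scatter) and no more than modest. For compound 3 the expected half-life is 0.022 h within a range of 0.012 h to 0.05 h and a reading at the limit remains possible.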

Compound 3, half-life: < 0.0167 h
Compound 3: a limit, no number; the forecaster's own chance of this, stated with the estimate: 45%; at least 1.3-fold (0.11 log units) between middle value and limit.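

In this assay, changing the trifluoromethyl on the oxygen to isopropyl gives an at least 2.4-fold lower number from compound 1 to compound 3 (0.39 log units; beyond the scatter). An oxygen on this aromatic carbon therefore does not by itself keep the half-life at the level of compound 1, and methyl is no longer the only replacement that falls short of trifluoromethoxy. The step between compound 2 and compound 3 cannot be read, as each reading is a limit and not a number: the limit of < 0.0167 h in this assay, at which 2 of the 3 values shown sit.

As far as these compounds go, how far compound 2 and compound 3 lie past that limit stays open. So does whether another group on this carbon, such as chlorine or a nitrile, would match trifluoromethoxy.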